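Ethyl-hydroxy piperidine in place of cyclopentylpiperazine

The source may report more compounds than this note shows. Statements on the series, on what has been measured and on what is new or still open speak of the compounds shown alone.

Measured compounds:
compound 1, `Cc1nc(N2CCN(C3CCCC3)CC2)nc2ccc(NC(=O)COc3ccc(Cl)cc3)cc12`, 96 nM
compound 2, `Cc1nc(N2CCC(C(=O)NC(C)C)CC2)nc2ccc(NC(=O)COc3ccc(Cl)cc3)cc12`, 15 nM
compound 3, `Cc1nc(N2CCC(O)CC2)nc2ccc(NC(=O)C(C)(C)Oc3ccc(Cl)cc3)cc12`, only a limit

In an assay on CHO-K1 cells for displacement of a labelled ligand from melanin-concentrating hormone receptor 1 (Homo sapiens), with a stated time of 2 h (on this read-out higher numbers stand for weaker inhibition and lower numbers for stronger inhibition), compound 1 gives 96 nM, the higher of the two numbers reported, while compound 2 gives 15 nM, a step well beyond the scatter of this assay. For compound 3 this assay reports only a limit, > 10000 nM, and not a number; it is one of the values at the limit of > 10000 nM in this assay, at which 1 of the 3 values shown sits. Compound 4, `CCC1(O)CCN(c2nc(C)c3cc(NC(=O)COc4ccc(Cl)cc4)ccc3n2)CC1`, differs from compound 1 in one place: 4-ethyl-4-hydroxypiperidin-1-yl in place of 4-cyclopentylpiperazin-1-yl on an aromatic carbon. Among the compounds with values here, since no pair of measured compounds shows this exact change, its effect can only be estimated. Within the data shown here, the hydroxyl donor that enters has no measured counterpart on the same core with the same acetamide chain, so the expectation is for a modest loss beyond the scatter, a 2.6-fold higher number from compound 1 to compound 4 (0.42 log units; beyond the scatter). Compound 4 is therefore estimated at 250 nM, with a range from 50 nM to 2500 nM.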

Compound 4, half-maximal inhibitory concentration: 208 nM
Beside the measured number, compound 4's estimate is 1.2-fold (0.08 log units) above it; the measured number falls inside the stated range.
By their numbers in this assay, from the lowest: compound 2; then compound 1; then compound 4. At a limit, above all of these: compound 3.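

In this assay, the position between two ring nitrogen atoms accepts 4-ethyl-4-hydroxypiperidin-1-yl in place of 4-cyclopentylpiperazin-1-yl at a modest cost, a 2.2-fold higher number from compound 1 to compound 4 (0.34 log units; beyond the scatter). This is the first single-place step shown at this position on the shared core: the five-membered ring of carbon leaves, a hydrogen-bond donor enters, and compound 4 still gives a number, 208 nM. Which of these differences accounts for the step cannot be said, and nothing measured here bears on its cause.

The compounds shown leave open whether the hydroxyl or the ethyl group matters more to this step. They also leave open how a methoxy group or a primary amine in place of the hydroxyl, or a longer chain in place of the ethyl, would read on the same core.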